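Replacing the Dichlorophenoxy Group of Compound 1 with a Thioether

The compounds below may be only part of what the source reports. "The series", "measured", "known", "first", "only" and "open" are said of these compounds alone.

Compound 1 `Nc1cc(N)c2nc(-c3ccccc3)c(Oc3ccc(Cl)c(Cl)c3)nc2c1` was examined in a functional assay on A498 cells (Homo sapiens) for inhibition, read by sulforhodamine B assay, with a stated time of 48 h; a higher number here means a weaker inhibitor of growth, a lower number a stronger inhibitor of growth. In this assay compound 1 gives only a limit, < 100000 nM. That limit is the one noted as the limit of < 100000 nM in this assay, at which 1 of the 2 values shown sits. Compound 2 `COc1cc(CNc2nc3cc(N)cc(N)c3nc2-c2ccccc2)cc(OC)c1OC` gives 14800 nM in this assay. Compound 3 `COc1ccc(Sc2nc3cc(N)cc(N)c3nc2-c2ccccc2)cc1` differs from compound 1 by (4-methoxyphenyl)sulfanyl in place of 3,4-dichlorophenoxy on an aromatic carbon. Among the compounds with values here, no measured step covers this exchange, so the expectation rests on the limit of compound 1 alone. A step toward stronger growth inhibition is expected, a step that the limit leaves unreadable from compound 1 to compound 3. Compound 3 is estimated at 20000 nM, with a range from 3000 nM to 100000 nM.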

Compound 3, concentration for total growth inhibition: 32400 nM
Estimate against measurement, compound 3: 1.6-fold (0.21 log units) below, within the range that was stated.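

Within the data shown here, no step from compound 1 to compound 3 can be read, because compound 1 gives only a limit in this assay: the limit of < 100000 nM in this assay, at which 1 of the 3 values shown sits. The compounds shown leave open how far (4-methoxyphenyl)sulfanyl in place of 3,4-dichlorophenoxy shifts growth inhibition.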